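Swapping allyl for 4-fluorophenyl on a weak starting compound

This account rests on a few compounds, and the source may have more. Where it says the series, first, only, none or still open, it means among the compounds named here.

Going by the values given here, in a functional assay on HCT-116 cells (Homo sapiens) for antiproliferative activity, read by MTT assay, with a stated time of 72 h (a higher number here means a weaker inhibitor, a lower number a stronger inhibitor), compound 1 `C=CC/N=C1\S/C(=C\c2ccc(OC)cc2)C(=O)N1C` gives 79300 nM, the only true number available so far. Compound 2 `COc1ccc(/C=C2\S/C(=N\c3cc(C(F)(F)F)cc(C(F)(F)F)c3)N(C)C2=O)cc1`, which has an aromatic ring on the double-bonded nitrogen, reads > 100000 nM, and this is a limit of the assay, not a number. Compound 3 `COc1ccc(/C=C2\S/C(=N\c3ccc(F)cc3)N(C)C2=O)cc1` keeps the core of compound 1 and changes one group: 4-fluorophenyl in place of allyl on a double-bonded nitrogen. In short, 4-fluorophenyl stands in place of allyl on a double-bonded nitrogen. Among the compounds with values here, no measured pair shows what such a swap does in this assay, and the only aromatic example, compound 2 at > 100000 nM, gives no sign of a gain. The expected size of a 1.3-fold lower number from compound 1 to compound 3 (0.12 log units; within the scatter) is therefore no larger than the usual scatter, with no firm direction. For compound 3, the estimated value is 60000 nM, with an expected range from 15000 nM to 100000 nM.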

Compound 3, half-maximal inhibitory concentration: 13300 nM
Compound 3: middle estimate off by 4.5-fold (0.65 log units), on the high side, and the stated range ends above it.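

Replacing allyl with 4-fluorophenyl on the double-bonded nitrogen gives, in this assay, a 6.0-fold lower number from compound 1 to compound 3 (0.78 log units; beyond the scatter). Going by these compounds alone, this is the first measured sign that the group at this place affects the result, and that an aromatic ring here can go with a stronger effect on the cells, though the step is modest. Compound 2, which also has an aromatic ring at this place, offers only a limit and no true number, so it cannot show how far this gain extends to other rings: the limit of > 100000 nM in this assay, at which 1 of the 3 values shown sits.

Still open, going by these compounds, is whether the gain comes from the ring itself or from its fluorine, a question that a plain phenyl group or a 4-methoxyphenyl group at this place would address. It is also unknown how an amine or a longer carbon chain would behave here, and why this change lowers the number at all.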